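A Nitrile Added to the Benzyl Ring of Compound 3

The source may report more compounds than this note shows. Statements on the series, on what has been measured and on what is new or still open speak of the compounds shown alone.

The measured compounds:
compound 1 `O=c1ccoc2cc(OCc3cn(Cc4ccccc4Br)nn3)ccc12`: 14500 nM
compound 2 `Cc1ccccc1Cn1cc(COc2ccc3c(=O)ccoc3c2)nn1`: 15300 nM
compound 3 `O=c1ccoc2cc(OCc3cn(Cc4ccccc4)nn3)ccc12`: > 100000 nM

Three compounds share one core and differ only in what sits on the benzyl ring. In a functional assay on HeLa cells (Homo sapiens) for cytotoxicity, read by MTT assay, with a stated time of 48 h (on this read-out higher numbers stand for weaker inhibition and lower numbers for stronger inhibition), compound 1 gives 14500 nM and compound 2 gives 15300 nM; the step of a 1.1-fold higher number from compound 1 to compound 2 (0.02 log units; within the scatter) is within the scatter. Compound 3 reaches only (the limit of > 100000 nM in this assay, at which 1 of the 3 values shown sits), so its value is a limit of the assay and not a number. Compound 3 thus stands at the weak end of the three, since an at least 6.8-fold higher number from compound 1 to compound 3 (0.83 log units; beyond the scatter) and an at least 6.5-fold higher number from compound 2 to compound 3 (0.81 log units; beyond the scatter) both lie beyond the scatter.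

Compound 4 `N#Cc1cccc(Cn2cc(COc3ccc4c(=O)ccoc4c3)nn2)c1` is the next step from compound 3: cyano in place of hydrogen on an aromatic carbon. The two steps that bear on it, an at least 6.8-fold higher number from compound 1 to compound 3 (0.83 log units; beyond the scatter) and an at least 6.5-fold higher number from compound 2 to compound 3 (0.81 log units; beyond the scatter), show that removing a group from this ring raised the number by at least a modest size, so putting a group back is expected to lower it. Going by the values given here, no measured step, however, places a cyano group on this ring, and the size of the effect is therefore uncertain. A step of an at least 2.5-fold lower number from compound 3 to compound 4 (0.39 log units; beyond the scatter) is expected. Compound 4 is estimated at 40000 nM, with a range from 12000 nM to 130000 nM.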

Compound 4, half-maximal inhibitory concentration: > 100000 nM
Compound 4 ended at the assay's limit; the forecaster's own chance of this, stated with the estimate: 35%; middle value at least 2.5-fold (0.39 log units) from the limit.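

In this assay compound 4 gives > 100000 nM, which is a limit of the assay and not a number, so it joins compound 3 at that limit: the limit of > 100000 nM in this assay, at which 2 of the 4 values shown sit.

Placing a cyano group on this ring, meta to a large group, thus gives no measurable value, so the earlier reading that a group on the benzyl ring lowers the number holds for compound 1 and compound 2, while compound 4 goes against it. The 3-cyanophenyl group also reads clearly apart from the two substituted rings that gave numbers, with an at least 6.5-fold higher number from compound 2 to compound 4 (0.81 log units; beyond the scatter) and an at least 6.8-fold higher number from compound 1 to compound 4 (0.83 log units; beyond the scatter), and the step between compound 3 and compound 4 cannot be read, with both compounds at the limit.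

The swap from 2-bromophenyl or 2-methylphenyl to 3-cyanophenyl changes both the group and its place on the ring, and the compounds shown do not separate the two. They also leave open how an amine, a carboxylic acid or a longer chain on this ring would read in this assay.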